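The source may hold more compounds than are shown below. What is called first, only, known or untested is meant among the compounds shown, and "the series" means these compounds.

Compound 1 `CCOC(=O)C(=O)Nc1cccccc1=O` carries only hydrogen on the seven-membered aromatic ring of carbon only; in a functional assay on the whole organism (strain Sprague-Dawley CD) for inhibition, with Rattus norvegicus as the target, read by paw edema, at a dose of 30 mg/kg by the intraperitoneal route (on this read-out higher numbers stand for a stronger effect at the one dose given and lower numbers for a weaker effect), compound 1 gives 84%. Compound 2 `CCOC(=O)C(=O)Nc1ccccc(O)c1=O` bears a hydroxy on an aromatic carbon, and in this assay compound 2 gives 61%. Compound 3 `CCOC(=O)C(=O)Nc1ccccc(OC)c1=O` bears a methoxy instead; in this assay compound 3 gives 52%, the number furthest from compound 1 among the three, though within the scatter of compound 2. The steps of a number 23 percentage points lower from compound 1 to compound 2 (beyond the scatter) and a number 32 percentage points lower from compound 1 to compound 3 (beyond the scatter) show that either group on that aromatic carbon lowers the read-out, while the step of a number 9 percentage points lower from compound 2 to compound 3 (within the scatter) stays within the scatter. Compound 4 `CCOC(=O)C(=O)Nc1ccccc(-c2ccccc2)c1=O` differs from compound 3 by phenyl in place of methoxy on an aromatic carbon. Going by the values given here, no measured step puts a phenyl at this place, so the bearing is indirect: both substituted compounds sit below compound 1, and the two substituted compounds sit close to each other. Compound 4 is therefore expected to land near compound 3, with a step of a number 7 percentage points lower from compound 3 to compound 4 (within the scatter) that should remain within the scatter. The estimate for compound 4 is 45%, in the range 25% to 65%.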

Compound 4, a percentage reported as inhibition, in the whole organism at one dose (the size of the read-out at that dose, not a potency): 72%
Compound 4: middle estimate off by 27 percentage points, on the low side; the measured number lies above the stated range.
By their numbers in this assay, from the lowest: compounds 3 and 2 (each within the scatter of the next); then compound 4; then compound 1.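

In this assay, a substituent on this aromatic carbon of the seven-membered aromatic ring does not always pull the read-out down as far as hydroxy and methoxy do: there is a number 20 percentage points higher from compound 3 to compound 4 (beyond the scatter) and a number 11 percentage points higher from compound 2 to compound 4 (beyond the scatter), even though phenyl is the largest of the three groups. Phenyl still gives a number 12 percentage points lower from compound 1 to compound 4 (beyond the scatter), so all three groups at this place stay under the hydrogen of compound 1, and the size of the loss depends on which group enters. No evidence is available to explain why phenyl differs from the other two groups.

The compounds shown leave open whether a methyl or a cyclohexyl at this place would read like phenyl or like methoxy. They also leave open whether any group here can match compound 1.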